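The source may hold more compounds than are shown below. What is called first, only, known or untested is meant among the compounds shown, and "the series" means these compounds.

Measured so far:
compound 1 `Cc1ccc(Nc2c(NCCCCCC(=O)NO)c(=O)c2=O)cc1` — 1800000 nM
compound 2 `O=C(CCCCCNc1c(Nc2ccc(C(F)(F)F)cc2)c(=O)c1=O)NO` — 4700000 nM

Within the data shown here, in a physicochemical assay for solubility, with a stated time of 24 h, tested at 30 mg/mL (a higher number here means a more soluble compound, a lower number a less soluble compound), compound 2 gives the higher of the two numbers; the only neighbour is compound 1, and the step of a 2.6-fold higher number from compound 1 to compound 2 (0.42 log units; beyond the scatter) separates them. Compound 3 `CCC(CCCCC(=O)NO)Nc1c(Nc2ccc(C(F)(F)F)cc2)c(=O)c1=O` differs from compound 2 by ethyl in place of hydrogen on a saturated chain carbon bound to a nitrogen on an aromatic ring and a saturated chain carbon. Among the measured compounds shown here, the single measured step concerns a different place, a change on the aromatic ring rather than on the saturated chain, so no measured step speaks directly to the addition of an ethyl on the chain carbon bound to the nitrogen on the aromatic ring. For the measured compounds named here, with no direct precedent, the expectation for this assay is no step beyond the scatter, with the estimated step of a 1.3-fold lower number from compound 2 to compound 3 (0.13 log units; within the scatter) kept small. Compound 3 is therefore expected to give about 3500000 nM in this assay, within a range of 1500000 nM to 7500000 nM.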

Compound 3, solubility: 25000000 nM
Compound 3: middle estimate off by 7.1-fold (0.85 log units), on the low side; measured number above the stated range.
By their numbers in this assay, from the lowest: compound 1; then compound 2; then compound 3.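

The saturated chain carbon bound to a nitrogen on an aromatic ring and a saturated chain carbon is a place where the read-out moves: in this assay, ethyl in place of hydrogen shows a 5.3-fold higher number from compound 2 to compound 3 (0.73 log units; beyond the scatter). The other step shown, a 2.6-fold higher number from compound 1 to compound 2 (0.42 log units; beyond the scatter), concerns an aromatic carbon, so the chain carbon is a second place with a step beyond the scatter, and both steps run upward. Nothing at hand accounts for the step at the chain carbon.

Going by these compounds, it remains open whether this step is specific to ethyl or would also appear with methyl, propyl or an amine on the same carbon. Also open, on these data alone, is whether ethyl gives a similar step when methyl, as in compound 1, stands in place of trifluoromethyl on the aromatic carbon.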